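Fluoro to methoxy on the aryl triazole arm

This account rests on a few compounds, and the source may have more. Where it says the series, first, only, none or still open, it means among the compounds named here.

Compound 1 `N#CC1=C(N)Oc2c(c3nc4ccccc4nc3c3ccccc23)C12C(=O)N(Cc1cnnn1-c1cccc(S(N)(=O)=O)c1)c1ccccc12`: 11300 nM
Compound 2 `Cc1ccc(Cl)cc1-n1nncc1CN1C(=O)C2(C(C#N)=C(N)Oc3c2c2nc4ccccc4nc2c2ccccc32)c2ccccc21`: > 50000 nM, a limit
Compound 3 `N#CC1=C(N)Oc2c(N)cc3nc4ccccc4nc3c2C12C(=O)N(Cc1cnnn1-c1ccc(F)cc1)c1ccccc12`: > 50000 nM, a limit

All values come from a functional assay on HCT-116 cells (Homo sapiens) for antiproliferative activity, read by MTT assay, with a stated time of 48 h; on this read-out lower numbers stand for stronger inhibition and higher numbers for weaker inhibition. Among the measured compounds shown here, compound 1 is the only member with a number; the other two sit at the limit. For compound 2 the value > 50000 nM is a limit of the assay, not a number. For compound 3 the value > 50000 nM is likewise a limit of the assay, so compound 3 stands at the weak end of what is shown, and (the limit of > 50000 nM in this assay, at which 2 of the 3 values shown sit) marks where it stands. For the measured compounds named here, the one measured step is an at least 4.4-fold higher number from compound 1 to compound 2 (0.64 log units; beyond the scatter): exchanging the aryl group on the triazole nitrogen moved the series to the limit.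

Compound 4 `COc1ccc(-n2nncc2CN2C(=O)C3(C(C#N)=C(N)Oc4c(N)cc5nc6ccccc6nc5c43)c3ccccc32)cc1` differs from compound 3 by methoxy in place of fluoro on an aromatic carbon. Going by the values given here, no measured step touches this position, and the change is small next to the step from compound 1 to compound 2. With compound 3 already at the limit, the exchange is expected to shift little in this assay, so the estimated step that the limit leaves unreadable from compound 3 to compound 4 is expected to remain within the scatter. Compound 4 is therefore estimated at 60000 nM, in the range 20000 nM to 200000 nM, most likely again reported as a limit.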

Compound 4, half-maximal inhibitory concentration: > 50000 nM
Compound 4: only a limit was reported; the forecaster's own chance of this, stated with the estimate: 75%; the middle value is on the limit's open side.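

Compound 3 and compound 4 both stand at a limit in this assay, so no step from compound 3 to compound 4 can be read: the limit of > 50000 nM in this assay, at which 3 of the 4 values shown sit.

The compounds shown leave open whether 4-fluorophenyl to 4-methoxyphenyl changes the read-out at all on a series member that gives a number rather than a limit.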